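The compounds below may be only part of what the source reports. "The series", "measured", "known", "first", "only" and "open" are said of these compounds alone.

Measured so far in a functional assay on DU-145 cells (Homo sapiens) for inhibition, read by trypan blue exclusion, with a stated time of 96 h (a lower number here means a stronger inhibitor of growth, a higher number a weaker inhibitor of growth), are three compounds.

- Compound 1 `Cc1ccc(CS/C(=C/c2c[nH]c3ccc(Br)cc23)C(=O)c2ccc(Cl)cc2)cc1` gives 1000 nM
- Compound 2 `Cc1ccc(/C=C(/SCc2ccc(Cl)cc2)C(=O)c2ccc(Cl)cc2)s1` gives 50000 nM
- Compound 3 `Cc1ccc(CS/C(=C/c2ccc(O)c(O)c2O)C(=O)c2ccc(Cl)cc2)cc1` gives 50000 nM

Compound 3 stands level with compound 2, and together they hold the highest of the three numbers. Compound 4 `Cc1ccc(CS/C(=C/c2ccc(C)s2)C(=O)c2ccc(Cl)cc2)cc1` differs from compound 3 by one swap 5-methylthiophen-2-yl in place of 2,3,4-trihydroxyphenyl on a double-bonded chain carbon bound to a double-bonded chain carbon and is still to be measured.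

For the measured compounds named here, the only measured step at this place is large and beyond the scatter: a 50-fold higher number from compound 1 to compound 3 (1.70 log units; beyond the scatter). That step shows that this place can matter, but it involves neither group entering here. The closer guide is compound 2, which also carries 5-methylthiophen-2-yl and gives 50000 nM in this reading.

No step beyond the scatter is therefore expected in this assay, and the expected change is a 1.4-fold lower number from compound 3 to compound 4 (0.15 log units; within the scatter) in this reading. For compound 4 the estimate is 35000 nM, with an expected range from 9000 nM to 80000 nM in this reading.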

Compound 4, concentration for 50% growth inhibition: 50000 nM
Estimate against measurement, compound 4: 1.4-fold (0.15 log units) below, within the range that was stated.
By their numbers in this assay, from the lowest: compound 1; then compounds 2, 3 and 4 (each within the scatter of the next).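

In this assay, the 5-methylthiophen-2-yl group matches 2,3,4-trihydroxyphenyl at this place, with no change at the digits printed from compound 3 to compound 4 (within the scatter), even though it has no hydrogen-bond donors. Methyl in place of chloro on an aromatic carbon also makes no difference at this level, with no change at the digits printed from compound 2 to compound 4 (within the scatter), while 5-bromo-1H-indol-3-yl remains the one group apart, with a 50-fold higher number from compound 1 to compound 4 (1.70 log units; beyond the scatter). No measured evidence here explains these results.

As far as these compounds go, what sets 5-bromo-1H-indol-3-yl apart remains open. So does whether a phenyl ring bearing an amine at this place would match it.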